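Benzyl for Isobutyl on a Shared Core

The source may hold more compounds than are shown below. What is called first, only, known or untested is meant among the compounds shown, and "the series" means these compounds.

Going by the values given here, compound 2 `Cc1nc(NCC(C)C)nc(N[C@@H]2C[C@H](CO)[C@@H](O)[C@H]2O)c1-c1nc2ccccc2s1` gives 10000 nM in an ADME assay on cells (Homo sapiens) for cytotoxicity, read by polymerase chain reaction, with a stated time of 3 days (a higher number here means that more compound is tolerated, a lower number that less compound is tolerated), the only number available here. Compound 1 `Nc1nc(Cl)c(-c2cc3ccccc3s2)c(N[C@@H]2C[C@H](CO)[C@@H](O)[C@H]2O)n1` reaches only a limit in this assay, > 25000 nM, which is the limit of > 25000 nM in this assay, at which 1 of the 2 values shown sits. Compound 3 `Cc1nc(NCc2ccccc2)nc(N[C@@H]2C[C@H](CO)[C@@H](O)[C@H]2O)c1-c1nc2ccccc2s1` has not yet been measured; it differs from compound 2 in one place, (phenyl in place of isopropyl on a saturated chain carbon bound to a nitrogen on an aromatic ring), so that isobutylamino becomes benzylamino. Among the compounds with values here, no step between measured compounds is available to set a scale, and the step of a 1.3-fold lower number from compound 2 to compound 3 (0.10 log units; within the scatter) is therefore expected to be small, within the scatter, in no clear direction. Compound 3 is expected to show about 8000 nM in this assay, within a range from 3000 nM to 25000 nM.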

Compound 3, half-maximal cytotoxic concentration: 9000 nM
For compound 3 the middle estimate is 1.1-fold (0.05 log units) below the measured one; the range from low to high includes it.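

In this assay, the change from isobutylamino to benzylamino gives a 1.1-fold lower number from compound 2 to compound 3 (0.05 log units; within the scatter), the first step read at this position. Phenyl in place of isopropyl adds a six-membered aromatic ring, yet compound 2 and compound 3 cannot be told apart here. Compound 1 remains the only compound at a limit: the limit of > 25000 nM in this assay, at which 1 of the 3 values shown sits.

Going by these compounds, whether an amine, a carboxylic acid or a longer chain in place of the phenyl would also leave the number within the scatter remains open. One step cannot show how far this tolerance extends.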